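This account rests on a few compounds, and the source may have more. Where it says the series, first, only, none or still open, it means among the compounds named here.

Measured so far:
compound 1, `CC(O)(CSc1ccc(F)cc1)c1nc(-c2ccc([N+](=O)[O-])c(C(F)(F)F)c2)no1`: 5100 nM
compound 2, `CC(O)(CSc1ccccc1)c1nc(-c2ccc([N+](=O)[O-])c(C(F)(F)F)c2)no1`: 3000 nM

Both numbers come from a functional assay on DU-145 cells (Homo sapiens) for cytotoxicity, read by MTT assay; on this read-out higher numbers stand for weaker inhibition and lower numbers for stronger inhibition. Compound 2 stands at 3000 nM; compound 1 stands at 5100 nM. The step of a 1.7-fold lower number from compound 1 to compound 2 (0.23 log units; within the scatter) lies within the scatter, so the two compounds are not separable on this assay.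

Compound 3, `CC(O)(CSc1ccc(Cl)cc1)c1nc(-c2ccc([N+](=O)[O-])c(C(F)(F)F)c2)no1`, has not been measured. It differs from compound 2 by chloro in place of hydrogen on an aromatic carbon; the phenylsulfanyl group of compound 2 becomes a (4-chlorophenyl)sulfanyl group, the new group sitting on an aromatic carbon of a six-membered aromatic ring of carbon only, para to a large group.

Among the measured compounds shown here, one measured step bears on this change: the exchange of fluoro for hydrogen at the same place, a 1.7-fold lower number from compound 1 to compound 2 (0.23 log units; within the scatter), which stayed within the scatter. From the compounds shown here alone, a halogen at this carbon has thus, in the single case seen, not moved the number beyond the scatter; chloro itself is untested, and nothing in the two compounds shows a direction for it.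

For compound 3 a step no larger than the scatter is expected, a 1.2-fold higher number from compound 2 to compound 3 (0.07 log units; within the scatter). The estimate for compound 3 in this assay is 3500 nM, with a range from 1500 nM to 8000 nM.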

Compound 3, half-maximal inhibitory concentration: 1300 nM
Compound 3: middle estimate off by 2.7-fold (0.43 log units), on the high side; the whole stated range lies above it.
By their numbers in this assay, from the lowest: compound 3; then compounds 2 and 1 (each within the scatter of the next).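

In this assay the aromatic carbon para to a large group proves sensitive to the halogen placed on it: chloro in place of hydrogen gives a 2.3-fold lower number from compound 2 to compound 3 (0.36 log units; beyond the scatter) and so lies beyond the scatter, which fluoro in place of hydrogen did not show. The two halogens are also not interchangeable at this carbon, as chloro in place of fluoro gives a 3.9-fold lower number from compound 1 to compound 3 (0.59 log units; beyond the scatter) and leaves compound 3 the strongest of the three, though both steps remain modest and each rests on a single pair. No supporting measurement accounts for the separation of chloro from fluoro here.

The compounds shown leave open whether bromo, methyl, methoxy or an amine at this carbon would follow chloro, fluoro or neither, so no trend across substituents can be drawn yet. They also leave open whether the effect of chloro carries over when the phenylsulfanyl link gives way to a phenoxy group or a longer chain, or when the nitro and trifluoromethyl groups on the other aromatic ring are exchanged.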